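The source may hold more compounds than are shown below. What is called first, only, known or untested is meant among the compounds shown, and "the series" means these compounds.

Measured so far, in a functional assay on A-431 cells (Homo sapiens) for cytotoxicity, read by MTT assay, with a stated time of 72 h, tested at 3 uM; on this read-out lower numbers stand for less inhibition of growth and higher numbers for more inhibition of growth at the one concentration tested:
- compound 1 `N/C(=N\NC(=S)N1CCCCCC1)c1ccccn1` gives 50.3%
- compound 2 `Cc1ccnc(/C(N)=N/NC(=S)N2CCSCC2)c1` gives 34.7%
- compound 3 `N/C(=N\NC(=S)N1CCSCC1)c1ccccn1` gives 37.2%

On these numbers compound 1 stands highest: compound 3 is the nearest, with a number that is lower by more than the scatter, and compound 2 is the furthest, also beyond the scatter. The unmeasured compound 4 `Cc1ccnc(/C(N)=N/NC(=S)N2CCCCCC2)c1` differs from compound 1 by methyl in place of hydrogen on an aromatic carbon, on an aromatic carbon of a six-membered aromatic ring with one nitrogen, meta to a large group and opposite the ring nitrogen.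

Within the data shown here, one measured step bears on this change, in the opposite direction: a number 2.5 percentage points higher from compound 2 to compound 3 (within the scatter). That step left the number essentially unchanged, so the same swap on the core of compound 1 is expected to give no step beyond the scatter in this assay . Compound 4 is therefore expected to land close to compound 1, with a number 2.3 percentage points lower from compound 1 to compound 4 (within the scatter), giving an estimate of 48% within a range of 35% to 60%.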

Compound 4, percent growth inhibition at one concentration: 36.1%
Compound 4: middle estimate off by 11.9 percentage points, on the high side; measured number inside the range.
By their numbers in this assay, from the lowest: compounds 2, 4 and 3 (each within the scatter of the next); then compound 1.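

Methyl in place of hydrogen on this aromatic carbon can matter in this assay, with a number 14.2 percentage points lower from compound 1 to compound 4 (beyond the scatter). Among these compounds, the earlier pair showed no step beyond the scatter for this swap, and this new step is the first that goes beyond it. Even so, the two cores cannot be said to respond differently, because the gap between their steps does not exceed what repeated measurements could produce: the same change on two cores in this assay, a number 2.5 percentage points higher (within the scatter) from compound 2 to compound 3 and a number 14.2 percentage points higher (beyond the scatter) from compound 4 to compound 1, 11.7 percentage points apart, within the scatter of two such steps

The compounds shown carry only hydrogen or methyl at this carbon, and whether the lower number is specific to methyl remains open. An ethyl, a methoxy or a chlorine at the same place, on both cores, would show whether the number tracks the group that enters.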